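The source may hold more compounds than are shown below. What is called first, only, known or untested is meant among the compounds shown, and "the series" means these compounds.

In a functional assay on MCF7 cells (Homo sapiens) for cytotoxicity, read by CellTiter-Glo, with a stated time of 5 days (a lower number here means a stronger inhibitor, a higher number a weaker inhibitor), the measured compounds gave:

Compound 1 `C/C(=C(/c1ccc(/C=C/C(=O)O)cc1)c1ccc2[nH]ncc2c1)c1ccccc1`: 40 nM
Compound 2 `CC/C(=C(/c1ccc(/C=C/C(=O)O)cc1)c1ccc2[nH]ncc2c1)c1ccccc1`: 7.2 nM
Compound 3 `O=C(O)/C=C/c1ccc(/C(=C(\c2ccccc2)C(F)F)c2ccc3[nH]ncc3c2)cc1`: 14 nM

Among these three, compound 3 stands second highest: it lies a 2.9-fold lower number from compound 1 to compound 3 (0.46 log units; beyond the scatter), while the gap a 1.9-fold higher number from compound 2 to compound 3 (0.29 log units; within the scatter) is within the scatter, so compound 2 and compound 3 cannot be ordered. Compound 4 `CC(C)/C(=C(/c1ccc(/C=C/C(=O)O)cc1)c1ccc2[nH]ncc2c1)c1ccccc1` carries isopropyl in place of difluoromethyl on a double-bonded chain carbon bound to an aromatic carbon and a double-bonded chain carbon. Among the measured compounds shown here, two steps bear on this: the step of a 5.6-fold lower number from compound 1 to compound 2 (0.74 log units; beyond the scatter) shows that a larger carbon-only group helped, and the step of a 1.9-fold higher number from compound 2 to compound 3 (0.29 log units; within the scatter) shows that ethyl and difluoromethyl sit close together. Isopropyl, another carbon-only group, is therefore expected to land near compound 2, giving an estimated step of a 1.6-fold lower number from compound 3 to compound 4 (0.19 log units; within the scatter). Compound 4 is expected at 9 nM, with a range of 3 nM to 30 nM.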

Compound 4, half-maximal inhibitory concentration: 4 nM
Compound 4: the middle estimate sits 2.3-fold (0.35 log units) above what was measured, within the range that was stated.
By their numbers in this assay, from the lowest: compounds 4, 2 and 3 (each within the scatter of the next, the first and the last beyond it); then compound 1.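

In this assay, isopropyl and difluoromethyl, each with the same count of heavy atoms, can be told apart at this position: the change gives a 3.5-fold lower number from compound 3 to compound 4 (0.54 log units; beyond the scatter), whereas ethyl and difluoromethyl could not be ordered. Adding one methyl to ethyl gives a 1.8-fold lower number from compound 2 to compound 4 (0.26 log units; within the scatter), so isopropyl and ethyl cannot be ordered either, though replacing the original methyl with isopropyl gives a 10-fold lower number from compound 1 to compound 4 (1.00 log units; beyond the scatter). Nothing measured here explains these differences. Still open, on these data alone, is how tert-butyl, cyclopropyl or trifluoromethyl would compare on this same carbon.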